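This account rests on a few compounds, and the source may have more. Where it says the series, first, only, none or still open, it means among the compounds named here.

Measured so far in an assay on isolated protein for binding affinity to corticotropin-releasing factor receptor 1 (Homo sapiens); a lower number here means a stronger inhibitor, a higher number a weaker inhibitor:
- compound 1, `CCCN(CCC)c1cc(C)nc2c(-c3ncc(N)cc3C)c(C)nn12`: 85 nM
- compound 2, `CCCN(CCC)c1cc(C)nc2c(-c3ncc(F)cc3C)c(C)nn12`: 19 nM

Going by the values given here, compound 2 holds the lower of the two numbers measured; the only neighbour, compound 1, sits higher, and the step of a 4.5-fold lower number from compound 1 to compound 2 (0.65 log units; beyond the scatter) lies beyond the scatter. The next compound, compound 3 `CCCN(CCC)c1cc(C)nc2c(-c3ncc(I)cc3C)c(C)nn12`, differs from compound 2 in one place: iodo in place of fluoro on an aromatic carbon. Among the compounds with values here, no measured step covers a change from one halogen to another; the single step recorded on this position, from amino to fluoro, was modest and ran toward a lower number. It shows that this carbon tolerates replacement without loss, but says nothing about a larger halogen. Without a direct precedent the change is expected to stay near the scatter, with no clear direction, as a 1.3-fold lower number from compound 2 to compound 3 (0.10 log units; within the scatter). Compound 3 is therefore estimated at 15 nM in this assay, within a range of 5 nM to 50 nM.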

Compound 3, inhibition constant: 6.6 nM
Estimate against measurement, compound 3: 2.3-fold (0.36 log units) above; low and high end bracket the measured number.
By their numbers in this assay, from the lowest: compound 3; then compound 2; then compound 1.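

In this assay, the halogens at this carbon are not interchangeable: the change from 5-fluoro-3-methylpyridin-2-yl to 5-iodo-3-methylpyridin-2-yl gives a 2.9-fold lower number from compound 2 to compound 3 (0.46 log units; beyond the scatter) and so adds a step beyond the scatter between two halogens, which the amino-to-fluoro step could not show. Measured against the amino group, iodo gives a 13-fold lower number from compound 1 to compound 3 (1.11 log units; beyond the scatter) and sets the order at this one carbon as iodo, then fluoro, then amino, with none of the three compounds going against it. Nothing at hand accounts for the difference between fluoro and iodo.

As far as these compounds go, whether chloro or bromo at this carbon would fall between fluoro and iodo stays open, as does the reading for a nitrile or a methoxy group there. Also open, from the compounds shown here alone, is whether the iodo gain carries over when the dipropylamino group on the shared core is replaced by a different amine.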